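Swapping a para chloro for a methyl on the benzyl arm

This account rests on a few compounds, and the source may have more. Where it says the series, first, only, none or still open, it means among the compounds named here.

Measured so far:
- compound 1 `Cc1ccccc1Nc1nc(SCc2cn(Cc3ccccc3Cl)nn2)nc(-c2ccccc2)c1C#N`: 9740 nM
- compound 2 `Cc1ccccc1Nc1nc(SCc2cn(Cc3ccc(Cl)cc3)nn2)nc(-c2ccccc2)c1C#N`: > 64000 nM

Both compounds share one core and differ only in the benzyl group attached to the ring nitrogen. In a functional assay on ECa-109 cells (Homo sapiens) for inhibition, read by MTT assay, with a stated time of 72 h (a higher number here means a weaker inhibitor, a lower number a stronger inhibitor), compound 1 gives 9740 nM. For compound 2 the assay reports only a limit, > 64000 nM, which is the limit of > 64000 nM in this assay, at which 1 of the 2 values shown sits. The step of an at least 6.5-fold higher number from compound 1 to compound 2 (0.81 log units; beyond the scatter) therefore shows that moving the chloro group from one position to the other costs a clear amount of activity, though the true size of the loss is not known beyond the limit.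

Compound 3 `Cc1ccc(Cn2cc(CSc3nc(Nc4ccccc4C)c(C#N)c(-c4ccccc4)n3)nn2)cc1` keeps the para substitution of compound 2 and changes only the substituent: methyl in place of chloro on an aromatic carbon. Going by the values given here, no measured pair covers a chloro to methyl exchange, so the only guide is that compound 2, the para-substituted parent, already sits at the limit. Compound 3 is expected to remain a weak inhibitor, with the step of an at least 1.2-fold lower number from compound 2 to compound 3 (0.10 log units; that floor lies within the scatter) estimated as small or none beyond the scatter. The estimated value for compound 3 in this assay is 50000 nM, within a range of 12000 nM to 200000 nM.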

Compound 3, half-maximal inhibitory concentration: > 64000 nM
Compound 3: a limit, no number; the forecaster's own chance of this, stated with the estimate: 60%; middle value at least 1.2-fold (0.10 log units) from the limit.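

With 4-methylphenyl in place of 2-chlorophenyl, this assay shows an at least 6.5-fold higher number from compound 1 to compound 3 (0.81 log units; beyond the scatter). The loss of activity seen with the 4-chlorophenyl arm is therefore not tied to chloro alone, since a methyl group para to a large group also leaves the compound far weaker than compound 1, which carries 2-chlorophenyl. Compound 3 gives > 64000 nM, which is a limit and not a number, and the step from compound 2 to compound 3 cannot be read, so chloro and methyl at this place cannot be ranked against each other: the limit of > 64000 nM in this assay, at which 2 of the 3 values shown sit.

Going by these compounds, whether a methoxy group, an amine or a carboxylic acid in this same place would bring a compound back to a measurable value remains open. Also open, on these data alone, is whether methyl in place of chloro on the arm of compound 1 would keep its activity, which would show if the arm tolerates a change of group at all when the position is kept.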